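Nitro for fluoro: from compound 2 to compound 4

The compounds below may be only part of what the source reports. "The series", "measured", "known", "first", "only" and "open" are said of these compounds alone.

For the measured compounds named here, compound 1 (`O=C1/C(=C/c2cccc(Br)c2)Cc2ccccc21`) gives 21000 nM in a functional assay on P388 cells (Mus musculus) for inhibition (on this read-out higher numbers stand for weaker inhibition and lower numbers for stronger inhibition), and holds the only numeric reading so far. Compound 2 (`O=C1CCCCC/C1=C\c1cccc(F)c1`) reads > 50000 nM as a limit of the assay, not a number. Compound 3 (`COc1ccc(/C=C2\CCCCCC2=O)cc1`) reads > 50000 nM as a limit too. Compound 2 therefore stands on the limit of > 50000 nM in this assay, at which 2 of the 3 values shown sit, and offers no exact starting number.

Compound 4 (`O=C1CCCCC/C1=C\c1cccc([N+](=O)[O-])c1`) carries nitro in place of fluoro on an aromatic carbon, and the counted difference from compound 2 is nitro in place of fluoro on an aromatic carbon in this one place. Going by the values given here, no measured pair shows this change. With compound 2 at > 50000 nM as its limit, the expected step in this assay is none beyond the scatter. The estimated at least 1.1-fold lower number from compound 2 to compound 4 (0.04 log units; that floor lies within the scatter) is nominal and is taken against a limit. For compound 4 the estimated value is 45000 nM with 15000 nM to 100000 nM as its expected range.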

Compound 4, half-maximal inhibitory concentration: 23600 nM
Estimate against measurement, compound 4: 1.9-fold (0.28 log units) above, within the range that was stated.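

For the compounds shown here, with nitro in place of fluoro on this aromatic carbon, compound 4 gives 23600 nM in this assay, the first numeric reading on the core of compound 2. Going by these compounds alone, the change amounts to an at least 2.1-fold lower number from compound 2 to compound 4 (0.32 log units; beyond the scatter), so this place on the aromatic ring can move the read-out beyond the scatter, which the earlier compounds could not show as no measured pair existed. The step is a floor and not a full size, because compound 2 stands on a limit of the assay and not on a number: the limit of > 50000 nM in this assay, at which 2 of the 4 values shown sit.

On these data alone, how an amine or a carboxylic acid at this aromatic carbon would read remains open. Also open, as far as these compounds go, is whether nitro in place of bromo would give a comparable step on the core of compound 1, which starts from a numeric reading.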